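The compounds below may be only part of what the source reports. "The series", "measured", "known", "first", "only" and "open" are said of these compounds alone.

Compound 1 `Cn1c(-c2cccc(Cl)c2)nc2c(NC3CCCC3)ncnc21` sits in a functional assay on CHO cells for antagonist activity at adenosine receptor A2b (Homo sapiens), read by 33P incorporation, with a stated time of 20 min (on this read-out higher numbers stand for weaker inhibition and lower numbers for stronger inhibition), at 2530 nM, the lowest of the two numbers shown, with compound 2 `CCCn1c(-c2ccccc2)nc2c(NC3CCCC3)ncnc21` nearest at 3430 nM, a gap within the scatter, so neither can be ordered above the other. Compound 3 `Cn1c(-c2ccc(Cl)cc2)nc2c(NC3CCCC3)ncnc21` gives in this assay > 30000 nM, a limit rather than a number. This is the limit of > 30000 nM in this assay, at which 1 of the 3 values shown sits. Within the data shown here, the single measured step that alters the aryl group, an at least 11-fold higher number from compound 1 to compound 3 (1.07 log units; beyond the scatter), is large, moving the value from a number to the limit when 4-chlorophenyl replaces 3-chlorophenyl.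

Compound 4 `Cn1c(-c2ccccc2)nc2c(NC3CCCC3)ncnc21` has not yet been measured. It differs from compound 1 by hydrogen in place of chloro on an aromatic carbon. Among the measured compounds shown here, no measured pair covers exactly this change: compound 2 also carries phenyl but differs from compound 4 in a second place as well, so the value of compound 2, 3430 nM, can only be taken as a loose guide. Since compound 2 sits within the scatter of compound 1, and the chloro in compound 1 is lost rather than moved, a modest weakening is expected, well short of what an at least 11-fold higher number from compound 1 to compound 3 (1.07 log units; beyond the scatter) showed. The expected step is a 2.0-fold higher number from compound 1 to compound 4 (0.30 log units; within the scatter). Compound 4 is therefore estimated at 5000 nM, in the range 1500 nM to 16000 nM.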

Compound 4, inhibition constant: 8510 nM
For compound 4 the middle estimate is 1.7-fold (0.23 log units) below the measured one; measured number inside the range.
By their numbers in this assay, from the lowest: compounds 1 and 2 (each within the scatter of the next); then compound 4. At a limit, above all of these: compound 3.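

In this assay, among these compounds, chloro at this place, meta to a large group, goes with a lower number than hydrogen, which the earlier compounds could not show: the change to phenyl gives a 3.4-fold higher number from compound 1 to compound 4 (0.53 log units; beyond the scatter), while with phenyl held fixed the shorter chain on the aromatic nitrogen gives a 2.5-fold higher number from compound 2 to compound 4 (0.39 log units; beyond the scatter). The unsubstituted phenyl also separates from the 4-chlorophenyl compound, with an at least 3.5-fold lower number from compound 3 to compound 4 (0.54 log units; beyond the scatter), so among these three methyl compounds, chloro goes with a lower number at one place and a higher number at the other, relative to hydrogen. Compound 3 gives > 30000 nM, which is a limit and not a number, so that side of the comparison has a bound and no end point: the limit of > 30000 nM in this assay, at which 1 of the 4 values shown sits.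

Going by these compounds, it remains open whether another group at the place of the chloro, such as a methoxy group, an amine or a carboxylic acid, would go with a lower number than chloro does. On these data alone, it is also open whether 3-chlorophenyl and the longer chain of compound 2 would act independently if combined on the shared core, or whether a still longer chain would continue the trend.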